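The source may report more compounds than this note shows. Statements on the series, on what has been measured and on what is new or still open speak of the compounds shown alone.

Measured so far:
- compound 1, `COc1ccc(C2=NO[C@]3(C2)C(=O)O[C@@H]2[C@H]3CC[C@H](C)[C@]3(O)C=CC(=O)[C@@]23C)cc1`: 41000 nM
- compound 2, `C[C@H]1CC[C@@H]2[C@@H](OC(=O)[C@]23CC(c2ccc(O)cc2)=NO3)[C@]2(C)C(=O)C=C[C@@]12O`: 89000 nM

In a functional assay on SW-620 cells (Homo sapiens) for cytotoxicity, read by sulforhodamine B assay, with a stated time of 48 h (a higher number here means a weaker inhibitor, a lower number a stronger inhibitor), compound 1 gives 41000 nM. In this assay compound 2 gives 89000 nM, the highest of the two numbers; its nearest neighbour is compound 1, reached by a 2.2-fold higher number from compound 1 to compound 2 (0.34 log units; beyond the scatter), a modest change beyond the scatter.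

Compound 3, `Cc1cccc(C2=NO[C@]3(C2)C(=O)O[C@@H]2[C@H]3CC[C@H](C)[C@]3(O)C=CC(=O)[C@@]23C)c1`, has not yet been measured. It differs from compound 2 as follows: 3-methylphenyl in place of 4-hydroxyphenyl on a carbon with a double bond to nitrogen. Going by the values given here, the only measured step that bears on this change is a 2.2-fold higher number from compound 1 to compound 2 (0.34 log units; beyond the scatter), where the aromatic ring carries an oxygen in both compounds; compound 3 keeps no oxygen on that ring, so the step is only a loose guide. It shows that the variant with the free hydroxyl sits at the weak end of the pair, so replacing the 4-hydroxyphenyl by 3-methylphenyl is expected to bring the number back toward that of compound 1 or slightly beyond, a modest step downward in this assay.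

For compound 3 the expected step is a 2.3-fold lower number from compound 2 to compound 3 (0.37 log units; beyond the scatter). Compound 3 is thus estimated at 38000 nM, with a range from 15000 nM to 100000 nM.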

Compound 3, half-maximal inhibitory concentration: 15000 nM
For compound 3 the middle estimate is 2.5-fold (0.40 log units) above the measured one, and the stated range covers the measured number.
By their numbers in this assay, from the lowest: compound 3; then compound 1; then compound 2.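

In this assay, the aryl group on the carbon with a double bond to nitrogen can do better without any oxygen on the ring: 3-methylphenyl in place of 4-hydroxyphenyl gives a 5.9-fold lower number from compound 2 to compound 3 (0.77 log units; beyond the scatter), and 3-methylphenyl in place of 4-methoxyphenyl gives a 2.7-fold lower number from compound 1 to compound 3 (0.44 log units; beyond the scatter). Among these three compounds, an oxygen on this ring is therefore not required for cytotoxicity, and compound 3, which carries none and has neither a hydrogen-bond donor nor a hydrogen-bond acceptor in this group, is the strongest of the three. Nothing measured here explains these differences.

The change replaces the group and moves its place on the ring in a single step, so the compounds shown cannot separate the effect of the methyl from the effect of where it sits. Also open, from the compounds shown here alone, is how an unsubstituted phenyl, or a ring carrying an amine or a carboxylic acid, would read in this assay, and whether any group at this position can bring the number far below those seen so far.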